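This account rests on a few compounds, and the source may have more. Where it says the series, first, only, none or still open, it means among the compounds named here.

Working notes on the sulfonamide series built on a shared core. Compound 1 `Cc1noc(C)c1S(=O)(=O)N1CCC(N2CCC(C)CC2)CC1` sits at a limit in a functional assay on DLD-1 cells (Homo sapiens) for antiproliferative activity, read by CellTiter-Glo, with a stated time of 72 h (a lower number here means a stronger inhibitor, a higher number a weaker inhibitor), where compound 1 gives > 5000 nM. Compound 2 `CC1CCN(C2CCN(S(=O)(=O)c3ccc(C#N)cc3)CC2)CC1` gives 2800 nM in this assay. Compound 3 `CC1CCN(C2CCN(S(=O)(=O)c3nccn3C)CC2)CC1` also stands only at a limit, giving > 5000 nM in this assay; see (the limit of > 5000 nM in this assay, at which 2 of the 3 values shown sit). The measured steps are an at least 1.7-fold lower number from compound 1 to compound 2 (0.25 log units; that floor lies within the scatter), an at least 1.7-fold higher number from compound 2 to compound 3 (0.25 log units; that floor lies within the scatter) and a step that the two limits leave unreadable from compound 1 to compound 3. Compound 4 `COc1cccc(S(=O)(=O)N2CCC(N3CCC(C)CC3)CC2)c1` carries 3-methoxyphenyl in place of 1-methyl-1H-imidazol-2-yl on a sulfonyl sulfur. The step bearing on this change is an at least 1.7-fold higher number from compound 2 to compound 3 (0.25 log units; that floor lies within the scatter), taken in reverse, of which only the floor is readable. The expected step is an at least 1.6-fold lower number from compound 3 to compound 4 (0.22 log units; that floor lies within the scatter), back toward the level of compound 2. Compound 4 is estimated at 3000 nM, within a range of 1000 nM to 9000 nM.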

Compound 4, half-maximal inhibitory concentration: > 5000 nM
Compound 4 gave a limit, no number (the forecaster's own chance of this, stated with the estimate: 40%); middle value at least 1.6-fold (0.22 log units) from the limit.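

Compound 4, with 3-methoxyphenyl on the sulfonyl sulfur, stands only at a limit in this assay, so a six-membered aromatic ring of carbon only does not by itself give a readable number at this position: the limit of > 5000 nM in this assay, at which 3 of the 4 values shown sit. Against 4-cyanophenyl, the result is an at least 1.7-fold higher number from compound 2 to compound 4 (0.25 log units; that floor lies within the scatter); the steps to compound 4 from compound 1 and compound 3 cannot be read. Among these compounds, compound 2 remains the only compound here with a number, but that floor does not separate it beyond the scatter.

Open, going by these compounds, is whether the nitrile of compound 2 matters in itself, and whether an amine or a carboxylic acid in its place would give a number.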